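The source may hold more compounds than are shown below. What is called first, only, known or untested is meant among the compounds shown, and "the series" means these compounds.

Working notes on the series in a functional assay on A549 cells (Homo sapiens) for antiproliferative activity, read by MTT assay, with a stated time of 72 h; a lower number here means a stronger inhibitor, a higher number a weaker inhibitor. Going by the values given here, compound 1 `NC1=NC2(CCOCC2)N(OCCCOc2cccc(Cl)c2)C(N)=N1` gives 150 nM and stands second highest of the three numbers measured so far. Compound 3 `NC1=NC2(CCOCC2)N(OCCCOc2cccc(Cl)c2Cl)C(N)=N1` gives 100 nM, and the step of a 1.5-fold lower number from compound 1 to compound 3 (0.18 log units; within the scatter) stays within the scatter. Compound 2 `Cc1ccc(OCCCON2C(N)=NC(N)=NC23CCOCC3)cc1` gives 1060 nM; the step of a 7.1-fold higher number from compound 1 to compound 2 (0.85 log units; beyond the scatter) is the one clear movement in the set, and an 11-fold lower number from compound 2 to compound 3 (1.03 log units; beyond the scatter) points the same way, so the measured shifts come from the aryl group on the oxygen of the saturated carbon, not from the shared core.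

Compound 4 `NC1=NC2(CCOCC2)N(OCCCOc2cccc(Br)c2)C(N)=N1` differs from compound 1 by bromo in place of chloro on an aromatic carbon. Among the compounds with values here, the nearest precedent is the step from compound 1 to compound 3, which added a chloro on the same ring and stayed within the scatter; no measured pair exchanges one halogen for another, so the exact change is uncovered. With a single aromatic halogen swapped for another of the same kind at the same place, no step beyond the scatter is expected in this assay, with at most a slight drift toward a lower number, in line with compound 3 at 100 nM. Compound 4 is therefore estimated at 130 nM, with a range from 60 nM to 300 nM. This estimate means an expected step of a 1.2-fold lower number from compound 1 to compound 4 (0.06 log units; within the scatter).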

Compound 4, half-maximal inhibitory concentration: 160 nM
Beside the measured number, compound 4's estimate is 1.2-fold (0.09 log units) below it; low and high end bracket the measured number.
By their numbers in this assay, from the lowest: compounds 3, 1 and 4 (each within the scatter of the next); then compound 2.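

In this assay, the exchange of 3-chlorophenyl for 3-bromophenyl, on an aromatic carbon meta to a large group, gives a 1.1-fold higher number from compound 1 to compound 4 (0.03 log units; within the scatter) and so leaves chloro and bromo indistinguishable at this place. The comparison with the dichlorinated ring gives a 1.6-fold higher number from compound 3 to compound 4 (0.20 log units; within the scatter) and likewise separates nothing, while a 6.6-fold lower number from compound 2 to compound 4 (0.82 log units; beyond the scatter) sets the 4-methylphenyl compound apart from a third halogenated aryl group, so compounds 1, 3 and 4 now form one group within the scatter and only compound 2 stands outside it. No measurement on hand offers a reason for the match between the two halogens.

The compounds shown cannot tell whether the weaker number of compound 2 follows from the methyl group itself or from its place on the ring, since that step changes both at once. Also open, from the compounds shown here alone, is whether a methoxy group or an amine at the place held by the halogen, or a longer chain joining the aryl ether to the shared core, would stay within this cluster.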